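The compounds below may be only part of what the source reports. "The series", "measured", "known", "first", "only" and "open" are said of these compounds alone.

Compound 3 `CCCN(CCC)c1cc(C)nc2c(-c3ncc(Cl)cc3C)c(C)nn12` gives 6.7 nM in an assay on isolated protein for binding affinity to corticotropin-releasing factor receptor 1 (Homo sapiens) (a lower number here means a stronger inhibitor, a higher number a weaker inhibitor), and holds the lowest of the three measured numbers. Compound 2 `CCCN(CCC)c1cc(C)nc2c(-c3ncc(N(CC)CC)cc3C)c(C)nn12` stands nearest, with 13 nM in this assay; the step of a 1.9-fold lower number from compound 2 to compound 3 (0.29 log units; within the scatter) stays within the scatter, so no order between these two can be claimed. Compound 1 `CCCN(CCC)c1cc(C)nc2c(-c3ccc(Cl)cn3)c(C)nn12` stands furthest, with 88 nM in this assay; the step of a 13-fold lower number from compound 1 to compound 3 (1.12 log units; beyond the scatter) is the only move in the set that clearly exceeds the scatter.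

Compound 4 `CCCN(CCC)c1cc(C)nc2c(-c3ncc(F)cc3C)c(C)nn12` differs from compound 3 by fluoro in place of chloro on an aromatic carbon. Of the measured steps, only a 1.9-fold lower number from compound 2 to compound 3 (0.29 log units; within the scatter) touches this position, and there the exchange of diethylamino for chloro shifted the number only within the scatter. The large step between compound 1 and compound 3 concerns the methyl group on a different carbon and does not bear on a halogen exchange. Among the measured compounds shown here, no measured pair shows fluoro against chloro anywhere. The expectation in this assay is therefore a step of no clear direction and no size beyond the scatter, estimated as a 1.5-fold higher number from compound 3 to compound 4 (0.17 log units; within the scatter). For compound 4 the estimate in this assay is 10 nM, with a range from 4 nM to 25 nM.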

Compound 4, inhibition constant: 19 nM
Estimate against measurement, compound 4: 1.9-fold (0.28 log units) below; measured number inside the range.
By their numbers in this assay, from the lowest: compounds 3, 2 and 4 (each within the scatter of the next, the first and the last beyond it); then compound 1.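

In this assay, among the compounds shown here, the exchange from 5-chloro-3-methylpyridin-2-yl to 5-fluoro-3-methylpyridin-2-yl supplies the first direct halogen pair at this place, two atoms from the ring nitrogen, and a 2.8-fold higher number from compound 3 to compound 4 (0.45 log units; beyond the scatter) shows that the position separates chloro from fluoro, modestly but beyond the scatter. Diethylamino cannot be separated from fluoro, since a 1.5-fold higher number from compound 2 to compound 4 (0.16 log units; within the scatter) stays within the scatter, as the step from compound 2 to chloro did, so compound 2 cannot be placed in an order with either halogen compound, although compound 3 and compound 4 stand apart. The 5-fluoro-3-methylpyridin-2-yl group also keeps a clear margin over 5-chloropyridin-2-yl, with a 4.6-fold lower number from compound 1 to compound 4 (0.67 log units; beyond the scatter), but that step changes both the halogen and the methyl group and so isolates neither.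

As far as these compounds go, whether a bromo or a methoxy group at this place would fall with chloro, with fluoro or outside both remains open, as does the effect of fluoro in a ring without the methyl group. The compounds come with no accompanying data that could explain the difference between the two halogens.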